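Chloro-to-methyl swap on the fused carbocyclic ring of a bis-amino core

The source may report more compounds than this note shows. Statements on the series, on what has been measured and on what is new or still open speak of the compounds shown alone.

Of the compounds shown here, three have been measured in a physicochemical assay for lipophilicity, at pH 7.4; a lower number here means a more polar compound, a higher number a more lipophilic compound. Compound 1 `CC(C)Nc1nc(NCc2ccco2)c2ccc(Cl)cc2n1` gives 3.91. Compound 2 `CC(C)Nc1nc(NCc2ccco2)c2c(Cl)cccc2n1`, whose core has the same atoms joined differently, gives 4.44; how its core differs from that of compound 1 is not broken down here. Compound 3 `Cc1ccc2c(NCc3ccco3)nc(NC(C)C)nc2c1` gives 3.61. Compound 2 gives the highest of the three numbers, beyond the scatter from both compound 1 and compound 3.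

One change is seen within the measured set: methyl in place of chloro on an aromatic carbon. Its step was a number 0.30 log units lower from compound 1 to compound 3 (within the scatter).

Compound 4 `Cc1cccc2nc(NC(C)C)nc(NCc3ccco3)c12` is not yet measured. It is related to compound 2 by methyl in place of chloro on an aromatic carbon. The place differs from the earlier case, meta and para to a fused ring there against ortho and meta to a fused ring here, so this is the same kind of change, not the same. The estimated step is a number 0.30 log units lower from compound 2 to compound 4 (within the scatter), which rests on a number 0.30 log units lower from compound 1 to compound 3 (within the scatter) as the nearest comparable case. For compound 4 the expected value in this assay is 4.14, with a range from 3.8 to 4.5.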

Compound 4, distribution coefficient: 3.55
For compound 4 the middle estimate is 0.59 log units above the measured one, and the stated range ends above it.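

In this assay, the change to methyl in place of chloro gives a number 0.89 log units lower from compound 2 to compound 4 (beyond the scatter), whereas the same kind of change on the core of compound 1 gives a number 0.30 log units lower from compound 1 to compound 3 (within the scatter); only the first of these steps lies beyond the scatter, so the size of the step did not carry from one core to the other in this series. This does not show what sets the size of the step, since each core supplies a single pair, and the place of the change, ortho and meta to a fused ring for compound 2 and compound 4, differs from that in the other pair. No measurement at hand bears on why the two steps differ.

The compounds shown leave open how an amine or a carboxylic acid would read at the place held by chloro in compound 2. They also leave open whether a further chloro and methyl pair on the shared core would follow either of the two steps.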